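Pyrazinecarbonyl boronic acid dipeptides: branching the central side chain

A few compounds are considered here, and "the series" means these few. Any claim that something is new, unique, unknown or untested is made for them only; others in the source may bear on it.

Compound 1: `CC(C)C[C@H](NC(=O)[C@@H](C)NC(=O)c1cnccn1)B(O)O` gives 433 nM in an assay on isolated protein for inhibition of Lon protease homolog, mitochondrial (Homo sapiens), read by HTRF, with a stated time of 50 min, in the presence of a further agent that is not named here; on this read-out lower numbers stand for stronger inhibition and higher numbers for weaker inhibition.
Compound 2: `CC[C@@H](NC(=O)c1cnccn1)C(=O)N[C@@H](CC(C)C)B(O)O` gives 408 nM in this assay.

Compound 2 and compound 1 are the only two measured, and the step of a 1.1-fold lower number from compound 1 to compound 2 (0.03 log units; within the scatter) leaves them within the scatter of each other. Compound 3, `CC(C)C[C@H](NC(=O)[C@H](NC(=O)c1cnccn1)C(C)C)B(O)O`, differs from compound 2 by methyl in place of hydrogen on a saturated chain carbon bound to two saturated chain carbons; read one bond further out, ethyl becomes isopropyl. For the measured compounds named here, only that one step bears on the change, and it carried no shift beyond the scatter. For compound 3 the expected step is therefore a 1.0-fold lower number from compound 2 to compound 3 (0.01 log units; within the scatter), none beyond the scatter. Compound 3 is estimated at 400 nM, with a range from 200 nM to 850 nM.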

Compound 3, half-maximal inhibitory concentration: 546 nM
Estimate against measurement, compound 3: 1.4-fold (0.14 log units) below; the range from low to high includes it.
By their numbers in this assay, from the lowest: compounds 2, 1 and 3 (each within the scatter of the next).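

In this assay, ethyl to isopropyl, methyl in place of hydrogen on a saturated chain carbon bound to two saturated chain carbons, gives a 1.3-fold higher number from compound 2 to compound 3 (0.13 log units; within the scatter), and isopropyl in place of methyl gives a 1.3-fold higher number from compound 1 to compound 3 (0.10 log units; within the scatter). Methyl, ethyl and isopropyl at this position thus all stand within the scatter of one another, so branching of the side chain adds no separation among these three compounds. No supporting measurement bears on this result. The compounds shown leave open whether a longer chain, a phenyl ring or an amine on this carbon would move the number beyond the scatter.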